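Cyano in place of fluoro: working notes

The source may hold more compounds than are shown below. What is called first, only, known or untested is meant among the compounds shown, and "the series" means these compounds.

compound 1 `COc1ccc(NC(=S)NNc2nncc3ccccc23)cc1` gives 47 nM
compound 2 `Fc1ccc(Nc2nncc3ccccc23)cc1` gives 4.7 nM

In a functional assay on UO-31 cells (Homo sapiens) for antiproliferative activity, read by sulforhodamine B assay, with a stated time of 72 h (on this read-out lower numbers stand for stronger inhibition and higher numbers for weaker inhibition), compound 2 holds the lower of the two numbers, beyond the scatter from compound 1. Compound 3 (`N#Cc1ccc(Nc2nncc3ccccc23)cc1`) is not yet measured and has cyano in place of fluoro on an aromatic carbon, para to a large group (cyano in place of fluoro on an aromatic carbon). Among the measured compounds shown here, no measured pair isolates this exchange, so the data give no direct guide to its size. A small rise in the number is expected in this assay and may stay within the scatter. The expected change is a 2.1-fold higher number from compound 2 to compound 3 (0.33 log units; beyond the scatter) on this estimate. Compound 3 is estimated at 10 nM with 3 nM to 40 nM as its expected range.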

Compound 3, half-maximal inhibitory concentration: 2 nM
The estimate for compound 3 lay 5.0-fold (0.70 log units) above the measured number; the whole stated range lies above it.
By their numbers in this assay, from the lowest: compound 3; then compound 2; then compound 1.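

In this assay, cyano in place of fluoro on an aromatic carbon, para to a large group, gives a 2.4-fold lower number from compound 2 to compound 3 (0.37 log units; beyond the scatter). Among the compounds shown here, this is the first measured step at this position, and it shows that the position accepts the cyano group with a modest gain in potency. No measurement shown here accounts for the gain.

On these data alone, it remains open whether an amine or a carboxylic acid at the same place would keep the number this low. A single step also leaves open whether the same exchange would carry the same size on another core.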